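The source may hold more compounds than are shown below. What is called first, only, known or untested is meant among the compounds shown, and "the series" means these compounds.

Working notes on the series. Compound 1 `CCCn1c(-c2ccco2)nc2c(N)nc(NCc3ccccc3)nc21` gives 29 nM in an assay on CHO cells for displacement of a labelled ligand from transmembrane domain-containing protein TMIGD3 (Homo sapiens); on this read-out higher numbers stand for weaker inhibition and lower numbers for stronger inhibition. Within the data shown here, compound 2 `CCCn1c(-c2ccco2)nc2c(N)nc(NCCCc3ccccc3)nc21` carries the change phenethyl in place of phenyl on a saturated chain carbon bound to a nitrogen on an aromatic ring and gives 266 nM in this assay; the step of a 9.2-fold higher number from compound 1 to compound 2 (0.96 log units; beyond the scatter) is the only measured instance of this change so far.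

Compound 3 `CCCn1c(-c2ccco2)nc2c(NCc3ccccc3)ncnc21` gives 402 nM in this assay. How its core differs from the core of compound 1 is not broken down here. Its value and that of compound 2 lie within the scatter of each other; against compound 1, the two values show compound 3 with the clearly higher number.

Compound 4 `CCCn1c(-c2ccco2)nc2c(NCCCc3ccccc3)ncnc21` is not yet measured. It stands to compound 3 as compound 2 stands to compound 1: the change (phenethyl in place of phenyl on a saturated chain carbon bound to a nitrogen on an aromatic ring), with the place described in the same words for both pairs, so it is the same change on a different core. Because the first instance moved the number by a 9.2-fold higher number from compound 1 to compound 2 (0.96 log units; beyond the scatter), a step of similar direction is expected from compound 3 to compound 4, estimated at a 6.2-fold higher number from compound 3 to compound 4 (0.79 log units; beyond the scatter) in this assay. Compound 4 is therefore expected to give about 2500 nM, with the estimate ranging from 800 nM to 8000 nM.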

Compound 4, inhibition constant: 959 nM
Estimate against measurement, compound 4: 2.6-fold (0.42 log units) above; the measured number falls inside the stated range.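

On the core of compound 3, the change again raises the number in this assay, with a 2.4-fold higher number from compound 3 to compound 4 (0.38 log units; beyond the scatter), so the direction seen on the core of compound 1 carries over to this second core. The size of the step does not carry over, and an estimate taken directly from one core would not hold for the other: the same change on two cores in this assay, a 9.2-fold higher number (0.96 log units; beyond the scatter) from compound 1 to compound 2 and a 2.4-fold higher number (0.38 log units; beyond the scatter) from compound 3 to compound 4, 3.8-fold (0.58 log units) apart, beyond the scatter of two such steps

These two pairs show a shared direction and a core-dependent size, but they do not explain the difference in size, and they give no rule for any further core.

Still open, as far as these compounds go, is how the number behaves on either core with a chain longer than 3-phenylpropyl, or with an amine or a carboxylic acid on the chain in place of the phenyl ring. Also open, from the compounds shown here alone, is whether other changes at this place would differ in size between the two cores as this one does.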